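Methoxy in Place of tert-Butyl on a Dihydrofolate Reductase Inhibitor

The source may report more compounds than this note shows. Statements on the series, on what has been measured and on what is new or still open speak of the compounds shown alone.

Compound 1 `CC(C)(C)c1ccc(OCCCON2C(N)=NC(N)=NC23CCSCC3)cc1` is the reference. In an assay on isolated protein for inhibition of Dihydrofolate reductase (Homo sapiens), read by spectrophotometry, using NADPH, with stated times of 5 s and 6 min, tested at 5 uM (on this read-out lower numbers stand for a weaker effect and higher numbers for a stronger effect at the one concentration tested), compound 1 gives 85.3%, the highest of the two plain numbers shown. Compound 3 `NC1=NC2(CCOCC2)N(OCCCOc2cccc(Cl)c2Cl)C(N)=N1` gives 81.7%, a gap to compound 1 that lies within the scatter. Compound 2 `NC1=NC2(CCOCC2)N(OCCCOc2ccc(Cl)cc2)C(N)=N1` gives > 90%, which is a limit of the assay rather than a number (the limit of > 90% in this assay, at which 1 of the 3 values shown sits). Going by the values given here, the only measured step, a number at least 8.3 percentage points lower from compound 2 to compound 3 (that floor lies within the scatter), concerns a change on the six-membered aromatic ring of carbon only and so bears only loosely on the present question. Compound 4 `COc1ccc(OCCCON2C(N)=NC(N)=NC23CCSCC3)cc1` differs from compound 1 by methoxy in place of tert-butyl on an aromatic carbon. Compound 4 is expected to give 80% in this assay, between 55% and 92%. The expected step of a number 5.3 percentage points lower from compound 1 to compound 4 (within the scatter) is estimated to stay within the scatter.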

Compound 4, a percentage reported as inhibition, at one concentration (the size of the read-out at that concentration, not a potency): 81.3%
Compound 4: middle estimate off by 1.3 percentage points, on the low side, and the stated range covers the measured number.
By their numbers in this assay, from the lowest: compounds 4, 3 and 1 (each within the scatter of the next). At a limit, above all of these: compound 2.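

Methoxy in place of tert-butyl on an aromatic carbon gives a number 4 percentage points lower from compound 1 to compound 4 (within the scatter) in this assay, the first step shown at this position, para to a large group. The read-out thus stays within the scatter when tert-butyl gives way to a smaller group that carries a hydrogen-bond acceptor. Compound 2 alone stands at a limit, not a number: the limit of > 90% in this assay, at which 1 of the 4 values shown sits.

From the compounds shown here alone, whether an amine or a carboxylic acid on this aromatic carbon would hold the read-out remains open. Going by these compounds, with one concentration tested, any difference in potency between compound 1 and compound 4 also remains open.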